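The source may hold more compounds than are shown below. What is called first, only, known or untested is meant among the compounds shown, and "the series" means these compounds.

Of the compounds shown here, three that share one core have been measured in a functional assay on CHO cells for antagonist activity at prostaglandin E2 receptor EP3 subtype (Homo sapiens), read by cAMP accumulation; on this read-out higher numbers stand for weaker inhibition and lower numbers for stronger inhibition. Compound 1 `CC(C)C(c1ncc[nH]1)c1ccc(-c2ccc3cccc(F)c3c2)[nH]c1=O` gives 33 nM in this assay, compound 2 `CC(C)C(Cc1ncc[nH]1)c1ccc(-c2ccc3cccc(F)c3c2)[nH]c1=O` gives 76 nM, and compound 3 `CC(C)C(/C=C1/CCNC1=O)c1ccc(-c2ccc3cccc(F)c3c2)[nH]c1=O` gives 8.1 nM. Compound 3 thus stands lowest of the three numbers, which here means the strongest inhibition: its nearest neighbour is compound 1, as shown by a 4.1-fold lower number from compound 1 to compound 3 (0.61 log units; beyond the scatter), and the furthest is compound 2, as shown by a 9.4-fold lower number from compound 2 to compound 3 (0.97 log units; beyond the scatter).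

Compound 4 `CC(C)C(c1ncco1)c1ccc(-c2ccc3cccc(F)c3c2)[nH]c1=O` has not yet been measured. It differs from compound 3 in one place: a group of 5 heavy atoms (3 carbon, 1 nitrogen, 1 oxygen; one five-membered aromatic ring with 2 hetero atoms) in place of a group of 7 heavy atoms (5 carbon, 1 nitrogen, 1 oxygen; one five-membered non-aromatic ring with 1 hetero atom), on a saturated chain carbon bound to an aromatic carbon and a saturated chain carbon. This is close to the reverse of the step from compound 1 to compound 3, since compound 1 also carries a five-membered aromatic ring with two hetero atoms on that chain carbon. Both that step and the related one, a 9.4-fold lower number from compound 2 to compound 3 (0.97 log units; beyond the scatter), show that going from an aromatic ring to the non-aromatic one lowered the number, so putting an aromatic ring back is expected to raise it. Going by the values given here, only one such aromatic ring on that carbon has been measured, so the size of the expected rise rests on a single step. Compound 4 is therefore expected to give about 45 nM in this assay, within a range of 15 nM to 150 nM, which amounts to an expected step of a 5.6-fold higher number from compound 3 to compound 4 (0.74 log units; beyond the scatter).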

Compound 4, half-maximal inhibitory concentration: 64 nM
Beside the measured number, compound 4's estimate is 1.4-fold (0.15 log units) below it, within the range that was stated.
By their numbers in this assay, from the lowest: compound 3; then compounds 1, 4 and 2 (each within the scatter of the next, the first and the last beyond it).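

In this assay, the change from the non-aromatic ring to 1,3-oxazol-2-yl gives a 7.9-fold higher number from compound 3 to compound 4 (0.90 log units; beyond the scatter) and thereby adds a second aromatic ring to the comparison, so the low number of compound 3 no longer stands against imidazole-bearing compounds alone. Replacing 1H-imidazol-2-yl with 1,3-oxazol-2-yl gives a 1.9-fold higher number from compound 1 to compound 4 (0.29 log units; within the scatter) and so does not separate these two aromatic rings on this saturated chain carbon, although 1,3-oxazol-2-yl has 0 hydrogen-bond donors. Replacing (1H-imidazol-2-yl)methyl with 1,3-oxazol-2-yl gives a 1.2-fold lower number from compound 2 to compound 4 (0.07 log units; within the scatter) and likewise does not separate these two groups, so among the groups shown only the non-aromatic ring of compound 3 stands apart from the others.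

Going by these compounds alone, compound 3 is the only example of its kind, which leaves open whether its low number needs the ring itself, the amide within it or the double bond joining it to the chain. A simple open-chain amide, a primary amine or a carboxylic acid on the same carbon would help to separate these possibilities, as would a six-membered aromatic ring such as pyridine for the aromatic series. Nothing shown here explains why these numbers differ.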